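A Pentylamino Chain in Place of Chloro

The compounds below may be only part of what the source reports. "The series", "measured", "known", "first", "only" and "open" are said of these compounds alone.

Compound 2 `O=C(NCc1ccccc1)c1cncc(Cl)n1` is recorded as "not determined" (no result reported) in an ADME assay on MDCK cells (Canis lupus familiaris) for cytotoxicity, read by microscopy, with a stated time of 6 days (on this read-out lower numbers stand for higher toxicity in this test and higher numbers for lower toxicity in this test), so it stands nowhere on the numbers shown. Its nearest measured relative, compound 1 `CCCCCCNc1cncc(C(=O)NCc2ccccc2)n1`, gives 20000 nM in this assay. Compound 3 `CCCCCNc1cncc(C(=O)NCc2ccccc2)n1` differs from compound 2 by pentylamino in place of chloro on an aromatic carbon. Within the data shown here, no measured pair shows this change, so its size cannot be read from data, and with no number for compound 2 the step itself cannot be given a value. Compound 3 is expected to sit close to compound 1, with no difference beyond the scatter, because compound 1 gives 20000 nM. Compound 3 is therefore estimated at 20000 nM, with a range from 10000 nM to 40000 nM.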

Compound 3, minimum cytotoxic concentration: 20000 nM
Compound 3: the middle estimate sits on the measured number at the digits printed; the range from low to high includes it.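

In this assay the two amino chains can be compared directly, and trimming the end of the chain gives no change at the digits printed from compound 1 to compound 3 (within the scatter). At this position, then, the pentylamino chain and the slightly longer hexylamino chain of compound 1 cannot be told apart on this read-out. Nothing available explains this result.

On these data alone, the step from compound 2 to compound 3 cannot be read, so what replacing chloro does stays unknown. Also open, as far as these compounds go, is whether an octylamino chain, or a shorter chain ending in a carboxylic acid, would read the same.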